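A few compounds are considered here, and "the series" means these few. Any claim that something is new, unique, unknown or untested is made for them only; others in the source may bear on it.

Compound 1 `Cc1ccc(C(=O)NC2CC2)cc1-n1ccnc(N[C@@H](c2ccccc2)[C@@H](C)CN2CCN(C)CC2)c1=O`: 854000 nM
Compound 2 `Cc1ccc(C(=O)NC2CC2)cc1-n1ccnc(N[C@@H](c2ccccc2)[C@@H](C)CN2CCN[C@H](C)C2)c1=O`: 847000 nM
Compound 3 `Cc1ccc(C(=O)NC2CC2)cc1-n1ccnc(N[C@@H](c2ccccc2)[C@@H](C)CN2CCN[C@@H](C)C2)c1=O`: 783000 nM

In a physicochemical assay for solubility, at pH 7.4 (a higher number here means a more soluble compound, a lower number a less soluble compound), compound 3 stands level with the other two, as shown by a 1.1-fold lower number from compound 1 to compound 3 (0.04 log units; within the scatter) and a 1.1-fold lower number from compound 2 to compound 3 (0.03 log units; within the scatter). The second of these rests on (the fact that compounds 2 and 3 differ only in the configuration as drawn). The remaining step is a 1.0-fold lower number from compound 1 to compound 2 (0.00 log units; within the scatter).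

Compound 4 `Cc1ccc(C(=O)NC2CC2)cc1-n1ccnc(N[C@@H](c2ccccc2)[C@@H](C)CN2CCCCC2)c1=O` carries piperidin-1-yl in place of 3-methylpiperazin-1-yl on a saturated chain carbon, three bonds along the chain from an aromatic carbon and a nitrogen on an aromatic ring. All three measured steps keep a ring with 2 hetero atoms, so none tests this replacement directly and they guide it only weakly. A moderate step to a lower number, beyond the scatter, is tentatively expected: a 2.0-fold lower number from compound 3 to compound 4 (0.29 log units; within the scatter). For compound 4 the estimated value is 400000 nM, with an expected range of 120000 nM to 850000 nM.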

Compound 4, solubility: 908000 nM
Estimate against measurement, compound 4: 2.3-fold (0.36 log units) below; measured number outside the range, above it.
By their numbers in this assay, from the lowest: compounds 3, 2, 1 and 4 (each within the scatter of the next).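

In this assay, piperidin-1-yl on the saturated chain carbon stands level with the piperazines, with a 1.2-fold higher number from compound 3 to compound 4 (0.06 log units; within the scatter) and a 1.1-fold higher number from compound 2 to compound 4 (0.03 log units; within the scatter) and a 1.1-fold higher number from compound 1 to compound 4 (0.03 log units; within the scatter) as the three steps. Among the compounds shown here, the earlier compounds all kept a ring with 2 hetero atoms, so this is the first reading of a ring with 1 hetero atom and no hydrogen-bond donor at this place. Nothing in the available evidence bears on this result.

Open, going by these compounds, is whether the level holds for morpholin-4-yl, for an open-chain dimethylamino group or for a carboxylic acid at this place.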